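The source may hold more compounds than are shown below. What is called first, only, known or untested is meant among the compounds shown, and "the series" means these compounds.

Series notes. Compound 1 `Cc1ccc(OCC(=O)N(Cc2cccs2)c2cnn(C)c2)cc1` gives 63000 nM in an assay on HEK293 cells for agonist activity at transient receptor potential cation channel subfamily M member 8 (Homo sapiens), read by fluorescence and calcium flux, with a stated time of 15 min (a lower number here means that less compound is needed, a higher number that more compound is needed for the effect), compound 2 `CCN(Cc1cccn1C)C(=O)COc1ccc(C)cc1` gives 21300 nM, and compound 3 `Cc1ccc(OCC(=O)N(Cc2cccs2)c2ccccc2)cc1` gives 23 nM. Compound 2 thus stands second highest of the three, nearer to compound 1 than to compound 3. Within the data shown here, the only one-place step measured is a 2700-fold lower number from compound 1 to compound 3 (3.44 log units; beyond the scatter), a change on an amide-type nitrogen. Compound 4 `CCN(Cc1ccncc1)C(=O)COc1ccc(C)cc1` differs from compound 2 by pyridin-4-yl in place of 1-methyl-1H-pyrrol-2-yl on a saturated chain carbon bound to an amide-type nitrogen. No measured step touches that saturated chain carbon, so the step from compound 1 to compound 3 does not bear directly on it; nothing shown points in either direction. Compound 4 is therefore expected to stay near compound 2, with the step of a 1.2-fold higher number from compound 2 to compound 4 (0.07 log units; within the scatter) expected to lie within the scatter. Compound 4 is estimated at 25000 nM, between 6000 nM and 100000 nM.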

Compound 4, half-maximal effective concentration: "not active" (no number reported)
The entry for compound 4 holds no number; there is nothing to compare the estimate with.
By their numbers in this assay, from the lowest: compound 3; then compound 2; then compound 1.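

Among these compounds, compound 4 is reported as "not active" with no number, so no step from compound 2 to compound 4 can be read. The compounds shown leave open how far pyridin-4-yl in place of 1-methyl-1H-pyrrol-2-yl shifts the number. Nothing shown accounts for this result.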